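This account rests on a few compounds, and the source may have more. Where it says the series, first, only, none or still open, it means among the compounds named here.

Measured compounds:
- Compound 1 `CCCc1cc(N)c2cc(NC(=O)/C=C/c3ccc(F)cc3)ccc2n1`: 130 nM
- Compound 2 `Nc1cc(C2CCC2)nc2ccc(NC(=O)/C=C/c3ccc(C(F)(F)F)cc3)cc12`: 2 nM
- Compound 3 `Cc1cc(N)c2cc(NC(=O)/C=C/c3ccc(C(F)(F)F)cc3)ccc2n1`: 8 nM

In an assay on isolated protein for displacement of a labelled ligand from melanin-concentrating hormone receptor 1 (Homo sapiens) (a higher number here means a weaker inhibitor, a lower number a stronger inhibitor), compound 1 gives the highest of the three numbers. Its nearest neighbour is compound 3, which in this assay gives 8 nM; the furthest is compound 2, which gives 2 nM. For the measured compounds named here, the one single-point step that has been measured, a 4.0-fold higher number from compound 2 to compound 3 (0.60 log units; beyond the scatter), concerns the group on the core and not the phenyl ring, so it does not bear on the change considered here.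

Compound 4 `CCCc1cc(N)c2cc(NC(=O)/C=C/c3ccccc3)ccc2n1` differs from compound 1 by hydrogen in place of fluoro on an aromatic carbon. Going by the values given here, no measured pair isolates this change: compounds 2 and 3 carry a trifluoromethyl on that ring and differ from compound 1 elsewhere as well, so their values show only that the two trifluoromethyl compounds sit well below compound 1 in this assay. Loss of a small substituent on the phenyl ring is therefore judged from general experience alone, and a small shift toward a higher number is expected, a 1.7-fold higher number from compound 1 to compound 4 (0.23 log units; within the scatter), though a result within the scatter would not surprise. For compound 4 the estimate in this assay is 220 nM, with a range from 90 nM to 500 nM.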

Compound 4, half-maximal inhibitory concentration: 1000 nM
Beside the measured number, compound 4's estimate is 4.5-fold (0.66 log units) below it, outside the stated range (above it).
By their numbers in this assay, from the lowest: compound 2; then compound 3; then compound 1; then compound 4.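

In this assay the change from 4-fluorophenyl to phenyl, on an aromatic carbon para to a large group, now has a measured single-point step of its own (a 7.7-fold higher number from compound 1 to compound 4 (0.89 log units; beyond the scatter)). For the compounds shown here, the earlier compounds offered no pair that isolated this place, so this is the first direct sign that one fluoro, a single heavy atom, counts for more than the scatter on this ring, at least in the setting of compound 1. Nothing at hand explains why so small a difference carries a step of this size.

The compounds shown leave open how other groups at this same place would rank against fluoro and hydrogen, for example a chloro, a methoxy or a nitrile, and how a trifluoromethyl would read on the otherwise unchanged frame of compound 1. They also leave open whether the loss of fluoro would give a step of similar size on a core carrying a methyl or a cyclobutyl in place of the chain of compound 1.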